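Methoxy for Chloro on the Pendant Phenyl Ring

The source may report more compounds than this note shows. Statements on the series, on what has been measured and on what is new or still open speak of the compounds shown alone.

Compound 1 `CCn1cc(-c2ccc(Cl)cc2)c(=O)c2cc(F)c(N3CCNCC3)cc21` and compound 3 `CCn1cc(-c2cccc(Cl)c2)c(=O)c2cc(F)c(N3CCNCC3)cc21` share a core and differ by 3-chlorophenyl in place of 4-chlorophenyl on an aromatic carbon. In a functional assay on HepG2 cells (Homo sapiens) for antiproliferative activity, read by MTT assay, with a stated time of 48 h (a higher number here means a weaker inhibitor, a lower number a stronger inhibitor), compound 1 gives 24000 nM, while compound 3 gives 15300 nM; the step of a 1.6-fold lower number from compound 1 to compound 3 (0.20 log units; within the scatter). Compound 2 `CCn1cc(-c2ccc(OC)cc2)c(=O)c2cc(F)c(N3CCNCC3)cc21` carries methoxy in place of chloro on an aromatic carbon relative to compound 1, and in this assay compound 2 gives 57900 nM, a step of a 2.4-fold higher number from compound 1 to compound 2 (0.38 log units; beyond the scatter). The same kind of change appears in compound 4 `CCn1cc(-c2cccc(OC)c2)c(=O)c2cc(F)c(N3CCNCC3)cc21`, which carries methoxy in place of chloro on an aromatic carbon relative to compound 3; here the methoxy sits meta to a large group rather than para to a large group. Because the earlier step of a 2.4-fold higher number from compound 1 to compound 2 (0.38 log units; beyond the scatter) was modest, a comparable weakening is expected for compound 4. For compound 4 the expected step is a 2.3-fold higher number from compound 3 to compound 4 (0.36 log units; beyond the scatter). Compound 4 is estimated at 35000 nM in this assay, within 15000 nM to 80000 nM.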

Compound 4, half-maximal inhibitory concentration: 13000 nM
Compound 4: the middle estimate sits 2.7-fold (0.43 log units) above what was measured; measured number below the stated range.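

In this assay, methoxy in place of chloro did not carry the same step from one core to the other: the same change on two cores in this assay, a 2.4-fold higher number (0.38 log units; beyond the scatter) from compound 1 to compound 2 and a 1.2-fold lower number (0.07 log units; within the scatter) from compound 3 to compound 4, 2.8-fold (0.45 log units) apart, beyond the scatter of two such steps On the second core the step reads a 1.2-fold lower number from compound 3 to compound 4 (0.07 log units; within the scatter), while 3-methoxyphenyl in place of 4-methoxyphenyl gives a 4.5-fold lower number from compound 2 to compound 4 (0.65 log units; beyond the scatter) and 3-methoxyphenyl in place of 4-chlorophenyl gives a 1.8-fold lower number from compound 1 to compound 4 (0.27 log units; within the scatter). This shows that, in these compounds, the step seen on one core does not predict the step on the other, but with a single pair on each core it gives no general rule and does not show why the two steps differ.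

The compounds shown leave open how an amine, a nitrile or a carboxylic acid on the phenyl ring would compare with chloro and methoxy. They also leave open whether the steps would hold with a longer chain in place of the ethyl group.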